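Carboxy to carbamoyl: what compound 3 may show

The source may hold more compounds than are shown below. What is called first, only, known or untested is meant among the compounds shown, and "the series" means these compounds.

Going by the values given here, in a physicochemical assay for solubility, read by nephelometry, in phosphate buffer, measured as kinetic solubility, at pH 6.5 (a higher number here means a more soluble compound, a lower number a less soluble compound), compound 2 (`O=C(Nc1ccc(C(=O)O)cc1)Nc1ccc(F)c(C(F)(F)F)c1`) gives 12.5 ug/mL, the higher of the two numbers so far, while compound 1 (`N#Cc1ccc(NC(=O)Nc2ccnc(C(F)(F)F)c2)cc1`) gives 1.6 ug/mL, a gap beyond the scatter. Compound 3 (`NC(=O)c1ccc(NC(=O)Nc2ccc(F)c(C(F)(F)F)c2)cc1`) is still unmeasured. It carries amino in place of hydroxy on a carbonyl carbon, a change from carboxy to carbamoyl (amino in place of hydroxy on a carbonyl carbon). Among the compounds with values here, no measured pair shows this change, so the expectation is tentative: a lower number in this assay, closer to compound 1 at 1.6 ug/mL. The estimated change is a 4.2-fold lower number from compound 2 to compound 3 (0.62 log units; beyond the scatter). For compound 3 the expected value is 3 ug/mL, with an estimated range of 1 ug/mL to 10 ug/mL.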

Compound 3, solubility: 6.3 ug/mL
Beside the measured number, compound 3's estimate is 2.1-fold (0.32 log units) below it; the range from low to high includes it.
By their numbers in this assay, from the lowest: compound 1; then compounds 3 and 2 (each within the scatter of the next).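

In this assay, amino in place of hydroxy on a carbonyl carbon gives a 2.0-fold lower number from compound 2 to compound 3 (0.30 log units; within the scatter) and so, at this position on the shared core, carboxy and carbamoyl are not separated by this read-out. Going by these compounds alone, this is the first pair in the set that differs in one place, and the change it shows stays within the scatter. Nothing available here bears on the reason for this result.

From the compounds shown here alone, what a methyl ester or a sulfonamide would give in the same place remains open. So does whether the same change would read alike on the core of compound 1.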